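Removing a methoxy group from a selenium-bearing indole chalcone

The source may hold more compounds than are shown below. What is called first, only, known or untested is meant among the compounds shown, and "the series" means these compounds.

Measured compounds:
Compound 1, `COc1ccc2c(/C=C/C(=O)c3cc(OC)c(OC)c(SC)c3)c[nH]c2c1`: 112 nM
Compound 2, `COc1cc(C(=O)/C=C/c2c[nH]c3ccccc23)cc(SC)c1OC`: 131 nM
Compound 3, `COc1ccc2c(/C=C(\C)C(=O)c3cc(OC)c(OC)c([Se]C)c3)c[nH]c2c1`: 6 nM

The three compounds above were tested in a functional assay on MHCC97H cells (Homo sapiens) for antiproliferative activity, read by MTT assay, with a stated time of 48 h; on this read-out higher numbers stand for weaker inhibition and lower numbers for stronger inhibition. Compound 1 gives 112 nM in this assay, and compound 2 gives 131 nM. These two differ in one place only: hydrogen in place of methoxy on an aromatic carbon. The resulting step, a 1.2-fold higher number from compound 1 to compound 2 (0.07 log units; within the scatter), shows that losing the methoxy group here leaves the read-out essentially unchanged.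

Compound 3 stands apart from the other two. In this assay compound 3 gives 6 nM, the lowest of the three numbers, and its gap to compound 1 and to compound 2 lies beyond the scatter. How the core of compound 3 differs from that of compound 1 involves more than one place, so that difference is not broken down here.

Compound 4, `COc1cc(C(=O)/C(C)=C/c2c[nH]c3ccccc23)cc([Se]C)c1OC`, has not been measured. It relates to compound 3 exactly as compound 2 relates to compound 1: hydrogen in place of methoxy on an aromatic carbon. Because the same change gave a 1.2-fold higher number from compound 1 to compound 2 (0.07 log units; within the scatter), a step of similar, small size is expected from compound 3 to compound 4, namely a 1.2-fold higher number from compound 3 to compound 4 (0.07 log units; within the scatter). On that basis compound 4 is estimated at 7 nM in this assay, with a plausible range from 3 nM to 16 nM. This rests on a single precedent pair, so the expectation is tentative.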

Compound 4, half-maximal inhibitory concentration: 18 nM
Compound 4: the middle estimate sits 2.6-fold (0.41 log units) below what was measured, and the stated range ends below it.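

In this assay, removing the methoxy group from the core that carries selenium gives a 3.0-fold higher number from compound 3 to compound 4 (0.48 log units; beyond the scatter), a modest loss of activity, whereas on the other core the same change gives a 1.2-fold higher number from compound 1 to compound 2 (0.07 log units; within the scatter). Although only the first of these steps stands clear of the usual variation between repeated measurements, the two steps cannot be told apart when set side by side: the same change on two cores in this assay, a 1.2-fold higher number (0.07 log units; within the scatter) from compound 1 to compound 2 and a 3.0-fold higher number (0.48 log units; beyond the scatter) from compound 3 to compound 4, 2.6-fold (0.41 log units) apart, within the scatter of two such steps. Carrying the change from one core to the other is therefore compatible with a single small effect, but with only one pair on each core this does not show that the effect is truly the same on both, and it says nothing about any further core.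

The compounds shown compare only methoxy and hydrogen at this place on the aromatic ring, so it remains open how a fluorine atom, a hydroxyl group or an ethoxy group would behave there on either core. Compound 3 also differs from compound 1 in more than one place, which leaves open how much of its lower number belongs to the selenium atom and how much to the added methyl group.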